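Notes on the series: replacing the oxan-4-yl group

The source may hold more compounds than are shown below. What is called first, only, known or untested is meant among the compounds shown, and "the series" means these compounds.

In a physicochemical assay for solubility, measured as kinetic solubility (a lower number here means a less soluble compound, a higher number a more soluble compound), compound 3 (`CCC/N=C1\S/C(=C\c2ccc(O)c(Cl)c2)C(=O)N1C1CCOCC1`) gives 70000 nM. Compound 1 (`CCC/N=C1\S/C(=C\c2ccc(O)c(Cl)c2)C(=O)N1C1CCS(=O)(=O)CC1`) gives 75000 nM, and compound 2 (`CCC/N=C1\S/C(=C\c2ccc(O)cn2)C(=O)N1c1ccccc1C`) gives 110000 nM. All three values lie within the scatter of one another, so compound 3 has no distinct rank among them.

The next compound, compound 4 (`CCC/N=C1\S/C(=C\c2ccc(O)c(Cl)c2)C(=O)N1C1CCN(C)C(=O)C1`), carries 1-methyl-2-oxopiperidin-4-yl in place of oxan-4-yl on an amide-type nitrogen in a ring.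

For the measured compounds named here, only one measured step bears on this place: a 1.1-fold lower number from compound 1 to compound 3 (0.03 log units; within the scatter), with oxan-4-yl in place of 1,1-dioxothian-4-yl. Going by the values given here, compound 2 differs from the others in more than one place and offers no single step. The new group itself has not been measured, so the evidence is thin, and no step beyond the scatter is expected. The estimated step is a 1.1-fold higher number from compound 3 to compound 4 (0.06 log units; within the scatter). For compound 4 the estimate is 80000 nM, with an expected range of 45000 nM to 140000 nM.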

Compound 4, solubility: > 250000 nM
Compound 4 was reported as a limit; the forecaster's own chance of this, stated with the estimate: 10%; middle value at least 3.1-fold (0.49 log units) from the limit.
By their numbers in this assay, from the lowest: compounds 3, 1 and 2 (each within the scatter of the next). At a limit, above all of these: compound 4.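

For the compounds shown here, at this position, on an amide-type nitrogen in a ring, oxan-4-yl and 1,1-dioxothian-4-yl lie within the scatter of each other in this assay, so the earlier compounds gave no sign that a change here could register. 1-Methyl-2-oxopiperidin-4-yl does register, with an at least 3.5-fold higher number from compound 3 to compound 4 (0.55 log units; beyond the scatter) and an at least 3.3-fold higher number from compound 1 to compound 4 (0.52 log units; beyond the scatter). Compound 4 stands as a limit, so both steps give only a lower bound: the limit of > 250000 nM in this assay, at which 1 of the 4 values shown sits.

The compounds shown do not separate the carbonyl from the methyl on the ring nitrogen, so neither can be tied to the step on its own. 1-Methylpiperidin-4-yl and 2-oxopiperidin-4-yl would pull the two apart, and whether the step carries over to the core of compound 2 also remains open.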